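Trifluoromethyl in place of chloro in a two-compound series

The source may hold more compounds than are shown below. What is called first, only, known or untested is meant among the compounds shown, and "the series" means these compounds.

In a functional assay on MCF7 cells (Homo sapiens) for inhibition, read by MTT assay, with a stated time of 72 h (on this read-out higher numbers stand for weaker inhibition and lower numbers for stronger inhibition), compound 1 (`COc1cc(NC(C)CCCNC(=O)NNC(=O)Nc2ccc(F)cc2)c2ncccc2c1`) gives 310 nM and compound 2 (`COc1cc(NC(C)CCCNC(=O)NNC(=O)Nc2ccc(Cl)cc2)c2ncccc2c1`) gives 180 nM as its half-maximal inhibitory concentration. Within the data shown here, compound 2 therefore stands within the scatter of compound 1, its only measured neighbour, and the two cannot be ranked against each other. Compound 3 (`COc1cc(NC(C)CCCNC(=O)NNC(=O)Nc2ccc(C(F)(F)F)cc2)c2ncccc2c1`) differs from compound 2 by a single change (trifluoromethyl in place of chloro on an aromatic carbon), trifluoromethyl in place of chloro on an aromatic carbon, para to a large group. Among the measured compounds shown here, the one measured step that bears on this carbon (a 1.7-fold lower number from compound 1 to compound 2 (0.24 log units; within the scatter)) is chloro in place of fluoro, and it lies within the scatter. For the measured compounds named here, that single step shows no trend, and no measured compound yet carries trifluoromethyl. Resting on that step (a 1.7-fold lower number from compound 1 to compound 2 (0.24 log units; within the scatter)), no change beyond the scatter is expected in this assay for the new group, in either direction. The expected step (a 1.1-fold higher number from compound 2 to compound 3 (0.05 log units; within the scatter)) is accordingly small, although the range around it has to stay wide. Compound 3 is estimated at 200 nM (range 90 nM to 450 nM).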

Compound 3, half-maximal inhibitory concentration: 100 nM
Estimate against measurement, compound 3: 2.0-fold (0.30 log units) above; measured number inside the range.
By their numbers in this assay, from the lowest: compounds 3, 2 and 1 (each within the scatter of the next, the first and the last beyond it).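

In this assay trifluoromethyl on this aromatic carbon gives a 1.8-fold lower number from compound 2 to compound 3 (0.26 log units; within the scatter) and so cannot be told apart from chloro, which leaves compound 2 and compound 3 unranked. Among these compounds, measured against fluoro, however, the same position gives a 3.1-fold lower number from compound 1 to compound 3 (0.49 log units; beyond the scatter) and this is the first step to clear the scatter, although only modestly. The position therefore accepts trifluoromethyl, with four heavy atoms, in place of a single halogen atom with no loss in this read-out, and the series now separates only at its two ends, compound 1 and compound 3, with chloro in compound 2 within the scatter of both.

Going by these compounds, whether a nitrile, an amine or a carboxylic acid on this carbon would stay with these three compounds or fall away from them remains open, as does whether the separation between fluoro and trifluoromethyl would hold in any other cell line. Nothing measured here accounts for that separation, so its cause stays unknown.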